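Sulfo for nitro on a shared oxindole core

The compounds below may be only part of what the source reports. "The series", "measured", "known", "first", "only" and "open" are said of these compounds alone.

Compound 2 `O=C1Nc2ccc([N+](=O)[O-])cc2C1(c1ccccc1)c1ccccc1` is measured in a functional assay on cells (Lung cancer cell line, Homo sapiens) for antiproliferative activity (a lower number here means a stronger inhibitor of growth, a higher number a weaker inhibitor of growth), where compound 2 gives 14000 nM. Among the compounds with values here, that is the only number recorded here; the one other result in this assay is a limit. Compound 1 `CCc1ccc2c(c1)C(c1ccccc1)(c1ccccc1)C(=O)N2` carries ethyl where compound 2 carries nitro. In this assay compound 1 gives > 20000 nM, which is a limit of the measurement rather than a number. The step of an at least 1.4-fold lower number from compound 1 to compound 2 (0.15 log units; that floor lies within the scatter) is therefore only a floor, and that floor lies within the scatter; it rests on (the limit of > 20000 nM in this assay, at which 1 of the 2 values shown sits).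

Compound 3 `O=C1Nc2ccc(S(=O)(=O)O)cc2C1(c1ccccc1)c1ccccc1` differs from compound 2 in one place: sulfo in place of nitro on an aromatic carbon. Within the data shown here, only the step from compound 1 to compound 2 bears on this change, it swaps one group on the same aromatic carbon, and it does not settle a direction beyond the scatter. For compound 3 an estimated step of a 1.6-fold higher number from compound 2 to compound 3 (0.20 log units; within the scatter) is expected, a shift toward the weaker side that may not exceed the scatter. Compound 3 is expected to give about 22000 nM, with a range from 8000 nM to 60000 nM, and a limit rather than a number is a real possibility.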

Compound 3, concentration for 50% growth inhibition: 9000 nM
Beside the measured number, compound 3's estimate is 2.4-fold (0.39 log units) above it, within the range that was stated.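

In this assay, sulfo in place of nitro on this aromatic carbon gives a 1.6-fold lower number from compound 2 to compound 3 (0.19 log units; within the scatter), so these two groups are not told apart here, even though sulfo carries a hydrogen-bond donor and nitro carries none. Sulfo in place of ethyl on the same carbon gives an at least 2.2-fold lower number from compound 1 to compound 3 (0.34 log units; beyond the scatter), the first step at this position to pass beyond the scatter. Compound 1 gives > 20000 nM, which is a limit rather than a number, and the step is therefore only a floor: the limit of > 20000 nM in this assay, at which 1 of the 3 values shown sits.

The compounds shown leave open how an amine, a carboxylic acid or a sulfonamide on this same aromatic carbon would read in this assay, and whether any group there would move the number clearly away from those of compound 2 and compound 3. The two phenyl groups of the shared core stay the same throughout the compounds shown, and what a smaller group such as methyl would do in their place remains open.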